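The source may hold more compounds than are shown below. What is called first, only, known or untested is meant among the compounds shown, and "the series" means these compounds.

Working notes on the hydroxyphenyl pyridyl ketone series. Going by the values given here, in a functional assay on HeLa cells (Homo sapiens) for cytotoxicity, read by sulforhodamine B assay, with a stated time of 48 h (a higher number here means a weaker inhibitor, a lower number a stronger inhibitor), compound 1 `O=C(c1cccnc1)c1ccccc1O` gives 33000 nM, the lowest of the two numbers so far, with compound 2 `O=C(c1cccnc1)c1ccc(Br)cc1O` nearest at 37000 nM in this assay. Among the compounds with values here, the step of a 1.1-fold higher number from compound 1 to compound 2 (0.05 log units; within the scatter), bromo in place of hydrogen on an aromatic carbon, is the only measured change and stays within the scatter.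

Compound 3 `O=C(c1cccnc1)c1cc(F)ccc1O` differs from compound 1 by fluoro in place of hydrogen on an aromatic carbon. Within the data shown here, the one step that bears on it, a 1.1-fold higher number from compound 1 to compound 2 (0.05 log units; within the scatter), puts a halogen onto the same carbon ring and moves the number only within the scatter; no other measured step touches this ring. The expectation for compound 3 in this assay is therefore a step of about no change at the digits printed from compound 1 to compound 3 (within the scatter), no change beyond the scatter in either direction. Compound 3 is estimated at 33000 nM, with a range from 15000 nM to 70000 nM.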

Compound 3, half-maximal inhibitory concentration: 27000 nM
Estimate against measurement, compound 3: 1.2-fold (0.09 log units) above; the measured number falls inside the stated range.
By their numbers in this assay, from the lowest: compounds 3, 1 and 2 (each within the scatter of the next).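

In this assay, fluoro on the aromatic carbon para to a hydroxy group gives a 1.2-fold lower number from compound 1 to compound 3 (0.09 log units; within the scatter), so at this position the change stays within the scatter. Alongside a 1.1-fold higher number from compound 1 to compound 2 (0.05 log units; within the scatter), this places a second halogen on another carbon of the same ring, and neither step leaves the scatter. No evidence is available on what lies behind this result.

From the compounds shown here alone, whether a group larger than a single halogen atom, or one of a different kind, would leave the number within the scatter at this position remains open. An amine, a carboxylic acid or a longer chain in place of the fluoro would test this, and the compounds shown give no step on the pyridine side of the core.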